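Thiazole alcohol replacing a saturated ring on the alkyne

The source may report more compounds than this note shows. Statements on the series, on what has been measured and on what is new or still open speak of the compounds shown alone.

Compound 2 `Cc1nc2ccc(C#CC3(O)CCCOC3)cc2n1-c1ncnc(N)n1` carries a ring-bearing alcohol on its alkyne. In an assay for binding affinity to serine/threonine-protein kinase PAK 1 (Homo sapiens), read by FRET and Z'-LYTE, with stated times of 10 min and 60 min (on this read-out lower numbers stand for stronger inhibition and higher numbers for weaker inhibition), compound 2 gives > 4500 nM, which is a limit of the assay rather than a number. Compound 1 `Cc1nc2ccc(C#CC(C)(C)CO)cc2n1-c1ncnc(N)n1` gives > 4500 nM in this assay, also a limit. Within the data shown here, the single measured step, a step that the two limits leave unreadable from compound 1 to compound 2, therefore cannot be read, as the limit of > 4500 nM in this assay, at which 2 of the 2 values shown sit, shows. Compound 3 `Cc1nc2ccc(C#C[C@@](C)(O)c3nccs3)cc2n1-c1ncnc(N)n1` differs from compound 2 by a group of 8 heavy atoms (5 carbon, 1 nitrogen, 1 oxygen, 1 sulfur; one five-membered aromatic ring with 2 hetero atoms) in place of a group of 7 heavy atoms (5 carbon, 2 oxygen; one six-membered non-aromatic ring with 1 hetero atom), on a triple-bonded carbon. No readable step bears on this change, so the measurements give no direction for it. For compound 3 the expected value is 6000 nM, within an estimated range of 1500 nM to 30000 nM, most likely again a limit. Among the measured compounds shown here, the expected step that the limit leaves unreadable from compound 2 to compound 3 is an estimate resting on no measured step.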

Compound 3, inhibition constant: > 4500 nM
Compound 3 was reported as a limit (the forecaster's own chance of this, stated with the estimate: 70%); the middle value lies beyond the limit too.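

Among these compounds, no step among compound 1, compound 2 and compound 3 can be read, since all three give only a limit, not a number: the limit of > 4500 nM in this assay, at which 3 of the 3 values shown sit. As far as these compounds go, whether any of these three groups on the triple-bonded carbon gives stronger inhibition than another remains open.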